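The source may report more compounds than this note shows. Statements on the series, on what has been measured and on what is new or still open speak of the compounds shown alone.

Measured compounds:
- compound 1, `N=C(N)c1ccc(-c2ccc(-c3cncc4ccccc34)s2)s1`: 880 nM in a functional assay on NCI-H460 cells (Homo sapiens) for inhibition, read by sulforhodamine B assay, with a stated time of 48 h; a higher number here means a weaker inhibitor of growth, a lower number a stronger inhibitor of growth
- compound 2, `N=C(N)c1ccc(-c2ccc(-c3ccc(F)cc3)o2)o1`: 1760 nM in this assay

Two compounds have numbers in this assay. Compound 2 gives 1760 nM there, and compound 1 gives 880 nM; the two values lie within the usual scatter of each other, so no order between them can be read from these numbers. Among the measured compounds shown here, the two compounds also differ in more than one place, so no single step is defined between them.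

Compound 3, `N=C(N)c1ccc(-c2ccc(-c3ccc(Cl)cc3)o2)o1`, is the next compound in the series and has not yet been measured. It differs from compound 2 by chloro in place of fluoro on an aromatic carbon. For the measured compounds named here, no measured pair in this set shows such a step, so nothing here tells the size of its effect. The expectation is a step from compound 2 to compound 3 of a 1.2-fold lower number from compound 2 to compound 3 (0.07 log units; within the scatter), in either direction and not beyond the scatter. For compound 3 in this assay the estimate is 1500 nM, with a range from 600 nM to 3800 nM.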

Compound 3, concentration for 50% growth inhibition: 1890 nM
Beside the measured number, compound 3's estimate is 1.3-fold (0.10 log units) below it; the range from low to high includes it.
By their numbers in this assay, from the lowest: compounds 1, 2 and 3 (each within the scatter of the next, the first and the last beyond it).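

Chloro in place of fluoro on an aromatic carbon, para to a large group, gives a 1.1-fold higher number from compound 2 to compound 3 (0.03 log units; within the scatter) in this assay. Among the compounds shown here, this is the first single-place step, and it shows that at this position on the six-membered aromatic ring of carbon only, this read-out does not separate the two halogens. No measurement on hand bears on this result.

Open, going by these compounds, is whether a group of another kind at this position, such as an amine, a methoxy group or a carboxylic acid, would give a step beyond the scatter. Also open, on these data alone, is whether the same exchange gives a like step on the core of compound 1, which differs from compound 2 in more than one place.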